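The source may report more compounds than this note shows. Statements on the series, on what has been measured and on what is new or still open speak of the compounds shown alone.

Measured so far:
- Compound 1, `CCCCCCCCOc1nc(N)nc2c1ncn2/C=C1/CC1(CO)CO`: in an ADME assay on BCBL1 cells (Homo sapiens) for cytotoxicity, with a stated time of 7 days (a lower number here means that less compound is tolerated, a higher number that more compound is tolerated), compound 1 gives > 20000 nM, which is a limit of the assay and not a number.
- Compound 2, `Nc1nc(N2CCCC2)c2ncn(/C=C3/CC3(CO)CO)c2n1`: in this assay compound 2 gives > 20000 nM, again a limit of the assay rather than a number.

Compound 2 therefore stands at the limit of > 20000 nM in this assay, at which 2 of the 2 values shown sit, with no measured number of its own. For the measured compounds named here, the one measured step, a step that the two limits leave unreadable from compound 1 to compound 2, is the exchange of one group on an aromatic carbon, but with both ends at a limit its size cannot be read.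

Compound 3, `CC(C)Sc1nc(N)nc2c1ncn2/C=C1/CC1(CO)CO`, is not yet measured. The change from compound 2 is isopropylsulfanyl in place of pyrrolidin-1-yl on an aromatic carbon. The measured step bears on it only by showing the same position being varied; it gives no size and no direction. With both values at a limit, no step beyond the scatter can be argued in either direction, and compound 3 is expected to sit near the same limit.

The expected step is a step that the limit leaves unreadable from compound 2 to compound 3. Compound 3 is estimated at 30000 nM, within 10000 nM to 100000 nM.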

Compound 3, half-maximal cytotoxic concentration: > 20000 nM
Compound 3: only a limit was reported; the forecaster's own chance of this, stated with the estimate: 85%; the middle value lies beyond the limit too.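

Compound 3 also gives only a limit of the assay and not a number, so its steps from compound 1 and from compound 2 cannot be read, and all three compounds stand at the same point: the limit of > 20000 nM in this assay, at which 3 of the 3 values shown sit.

The compounds shown leave open whether exchanging the group on this aromatic carbon changes the tolerated concentration in this assay at all, and by how much.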